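This account rests on a few compounds, and the source may have more. Where it says the series, first, only, none or still open, it means among the compounds named here.

In an in vivo ADME assay on the whole organism (plasma) for pharmacokinetics, with Rattus norvegicus as the target, at a dose of 50 mg/kg by the oral route (a higher number here means more compound in the circulation at the dose given, a lower number less compound in the circulation), compound 3 (`CCCS(=O)(=O)c1cc(C)cc(C)c1NC(=O)c1sccc1S(=O)(=O)Nc1onc(C)c1Cl`) gives 5450 nM and stands within the scatter of compound 1 (`CC(=O)OCc1c(C)cc(C)c(NC(=O)c2sccc2S(=O)(=O)Nc2onc(C)c2Cl)c1C`) at 7420 nM; compound 2 (`Cc1cc(C)c(NC(=O)c2sccc2S(=O)(=O)Nc2onc(C)c2Cl)c(C)c1O`) gives 106000 nM and stands well above both. The next structure is compound 4 (`Cc1cc(C)c(NC(=O)c2sccc2S(=O)(=O)Nc2onc(C)c2Cl)c(C(=O)CS(C)(=O)=O)c1`), with ((methylsulfonyl)methyl)carbonyl in place of propylsulfonyl on an aromatic carbon. Going by the values given here, one measured step bears on this, and only loosely: a 14-fold higher number from compound 1 to compound 2 (1.15 log units; beyond the scatter) for hydroxy in place of acetoxymethyl on an aromatic carbon, which is a different exchange from the one at hand. Compound 4 carries no hydroxy, and the two measured compounds without one, compound 1 at 7420 nM and compound 3 at 5450 nM, lie within the scatter of each other. Among the compounds with values here, no large step is therefore carried over. In this assay the expected step is a 1.3-fold higher number from compound 3 to compound 4 (0.11 log units; within the scatter) and no change beyond the scatter is foreseen. For compound 4 the estimated value is 7000 nM (expected range 2000 nM to 25000 nM).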

Compound 4, maximal plasma concentration: 68300 nM
The estimate for compound 4 lay 9.8-fold (0.99 log units) below the measured number; measured number above the stated range.
By their numbers in this assay, from the lowest: compounds 3 and 1 (each within the scatter of the next); then compounds 4 and 2 (each within the scatter of the next).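

In this assay the aromatic carbon ortho to a large group proves sensitive to the group it carries: ((methylsulfonyl)methyl)carbonyl in place of propylsulfonyl gives a large step (a 13-fold higher number from compound 3 to compound 4 (1.10 log units; beyond the scatter)). Going by these compounds alone, the only earlier large step brought in hydroxy at a different place, whereas the group entering here has no hydrogen-bond donors, so a large rise does not require a donor to enter. Both groups are uncharged and have no ring, and nothing measured on these compounds accounts for the step.

This single exchange alters the attached carbonyl, the sulfonyl and the chain together, so the part that carries the step cannot be separated. From the compounds shown here alone, how a plain acetyl or a carboxylic acid would behave at this position remains open.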